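The source may report more compounds than this note shows. Statements on the series, on what has been measured and on what is new or still open speak of the compounds shown alone.

The measured compounds are compound 1, `CN1C(=O)C(c2ccccc2)CC(c2ccccc2)C1=O`, compound 2, `O=C1C(c2ccccc2)CC(c2ccccc2)C(=O)N1c1cccc(Cl)c1`, and compound 3, `O=C1NC(=O)C(c2ccccc2Cl)CC1c1ccccc1Cl`. In a functional assay on the whole organism (strain Swiss albino) for inhibition, with Mus musculus as the target, in the maximal electroshock model, with a stated time of 2 h, at a dose of 25 mg/kg by the intraperitoneal route (a lower number here means less inhibition, a higher number more inhibition at the dose given (going by the name of the read-out)), compound 1 gives 69.1%, compound 2 gives 32.2% and compound 3 gives 58.3%.

Compound 3 stands second of the three measured numbers: compound 1 lies higher and compound 2 lies lower, both beyond the scatter. Compound 4, `Cc1ccccc1N1C(=O)C(c2ccccc2Cl)CC(c2ccccc2Cl)C1=O`, has not yet been measured; it differs from compound 3 by 2-methylphenyl in place of hydrogen on an amide-type nitrogen in a ring. Within the data shown here, the one measured step that bears on this place is a number 36.9 percentage points lower from compound 1 to compound 2 (beyond the scatter), where an aromatic ring likewise replaced a smaller group on the same nitrogen. A drop of similar kind is therefore expected for compound 4, though the two changes are not identical. The expected step is a number 23.3 percentage points lower from compound 3 to compound 4 (beyond the scatter). Compound 4 is estimated at 35%, in the range 15% to 58%.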

Compound 4, a percentage reported as inhibition, in the whole organism at one dose (the size of the read-out at that dose, not a potency): 60.6%
For compound 4 the middle estimate is 25.6 percentage points below the measured one; measured number outside the range, above it.
By their numbers in this assay, from the lowest: compound 2; then compounds 3, 4 and 1 (each within the scatter of the next, the first and the last beyond it).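

In this assay, 2-methylphenyl in place of hydrogen on the amide-type nitrogen in the ring gives a number 2.3 percentage points higher from compound 3 to compound 4 (within the scatter), so on this core the nitrogen carries an aromatic ring without a change beyond the scatter. An aromatic ring here therefore does not always go with a drop like a number 36.9 percentage points lower from compound 1 to compound 2 (beyond the scatter), a step that replaced methyl with 3-chlorophenyl on a core with plain phenyl groups. Nothing available explains why the two steps differ.

On these data alone, it remains open how 2-methylphenyl would behave on the core with plain phenyl groups. As far as these compounds go, it is also open how a longer chain such as butyl, or a chain ending in a carboxylic acid, would behave on this nitrogen.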